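Fluoro for methyl on a quinazoline-hydrazone series

The source may hold more compounds than are shown below. What is called first, only, known or untested is meant among the compounds shown, and "the series" means these compounds.

Of the compounds shown here, three sharing a common core have been tested in a functional assay on SGC-7901 cells (Homo sapiens) for cytotoxicity, read by MTT assay, with a stated time of 72 h; a lower number here means a stronger inhibitor, a higher number a weaker inhibitor. Compound 1 `Cc1ccc(Cn2ccnc2/C=N/Nc2nc(NCCN(C)C)c3ccccc3n2)cc1` gives 2750 nM in this assay, compound 2 `CN(C)CCNc1nc(N/N=C/c2nccn2Cc2ccc(F)cc2)nc2ccccc12` gives 2420 nM, and compound 3 `Cc1ccc(Cn2ccnc2/C=N/Nc2nc(NCCCN(C)C)c3ccccc3n2)cc1` gives 2600 nM. The three numbers sit close together, and neither the step of a 1.1-fold lower number from compound 1 to compound 2 (0.06 log units; within the scatter) nor the step of a 1.1-fold lower number from compound 1 to compound 3 (0.02 log units; within the scatter) goes beyond the usual scatter.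

Compound 1 and compound 2 differ in one place, described as fluoro in place of methyl on an aromatic carbon. The cores of compound 1 and compound 3 differ in the way described as (dimethylamino)methyl in place of dimethylamino on a saturated chain carbon, two bonds along the chain from a nitrogen on an aromatic ring, so compound 3 carries the longer chain on the nitrogen attached to the aromatic ring.

Compound 4 `CN(C)CCCNc1nc(N/N=C/c2nccn2Cc2ccc(F)cc2)nc2ccccc12` has not yet been measured. It relates to compound 3 exactly as compound 2 relates to compound 1: the difference is fluoro in place of methyl on an aromatic carbon, and its place reads the same, word for word, as in the earlier pair, so it is the same change made on the core of compound 3. Because the earlier instance gave a 1.1-fold lower number from compound 1 to compound 2 (0.06 log units; within the scatter), the step of a 1.1-fold lower number from compound 3 to compound 4 (0.04 log units; within the scatter) is expected to be of similar modest size, lying within the scatter. On that basis compound 4 is estimated to give 2350 nM in this assay, with a plausible range from 1200 nM to 4700 nM.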

Compound 4, half-maximal inhibitory concentration: 3510 nM
Compound 4: the middle estimate sits 1.5-fold (0.17 log units) below what was measured, within the range that was stated.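

In this assay, fluoro in place of methyl on the core of compound 3 gives a 1.4-fold higher number from compound 3 to compound 4 (0.13 log units; within the scatter), and this does not separate from the earlier instance of the same change: the same change on two cores in this assay, a 1.1-fold lower number (0.06 log units; within the scatter) from compound 1 to compound 2 and a 1.4-fold higher number (0.13 log units; within the scatter) from compound 3 to compound 4, 1.5-fold (0.19 log units) apart, within the scatter of two such steps. The longer chain, read on the core of compound 2, gives a 1.5-fold higher number from compound 2 to compound 4 (0.16 log units; within the scatter), and it likewise agrees with its earlier instance: the same change on two cores in this assay, a 1.1-fold lower number (0.02 log units; within the scatter) from compound 1 to compound 3 and a 1.5-fold higher number (0.16 log units; within the scatter) from compound 2 to compound 4, 1.5-fold (0.19 log units) apart, within the scatter of two such steps. Across these four compounds, then, both changes carry from one core to the other without any step or gap going beyond the scatter, but this shows only that neither change has a measurable effect here on either core; it does not show a real effect of either change, a direction for one, or any dependence of one change on the other.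

The compounds shown leave open whether a step beyond the scatter would appear with other groups in place of the 4-fluorobenzyl or 4-methylbenzyl, such as 4-chlorobenzyl or 4-methoxybenzyl. They also leave open whether a still longer chain, or a diethylamino group in place of dimethylamino, would move the number in this assay.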